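Notes on the sulfamate series: extending the ethyl chain

A few compounds are considered here, and "the series" means these few. Any claim that something is new, unique, unknown or untested is made for them only; others in the source may bear on it.

Three compounds share one core carrying a sulfamate group and differ at the nitrogen on the aromatic ring of the benzamide part. Compound 1 `CCN(Cc1ccc(Br)cc1)c1ccc(C(=O)N2CCc3ccc(OS(N)(=O)=O)cc3C2)cc1` gives 95.9% in an assay on HEK293 cells for inhibition of Steryl-sulfatase (Homo sapiens), tested at 1 uM; a lower number here means a weaker effect, a higher number a stronger effect of the compound at the concentration tested. Compound 2 `NS(=O)(=O)Oc1ccc2c(c1)CN(C(=O)c1ccc(N3CCCCC3)cc1)CC2` gives 38.3%, and compound 3 `CCN(Cc1ccccc1)c1ccc(C(=O)N2CCc3ccc(OS(N)(=O)=O)cc3C2)cc1` gives 83.6%. Compound 3 therefore stands second of the three: a number 12.3 percentage points lower from compound 1 to compound 3 (beyond the scatter), while a number 45.3 percentage points higher from compound 2 to compound 3 (beyond the scatter). The next compound, compound 4 `CN(C)CCN(Cc1ccccc1)c1ccc(C(=O)N2CCc3ccc(OS(N)(=O)=O)cc3C2)cc1`, has not yet been measured. Relative to compound 3 the change is dimethylamino in place of hydrogen on a saturated chain carbon, two bonds along the chain from a nitrogen on an aromatic ring. Among the measured compounds shown here, no measured step touches this chain: a number 57.6 percentage points lower from compound 1 to compound 2 (beyond the scatter) and a number 45.3 percentage points higher from compound 2 to compound 3 (beyond the scatter) exchange the whole group on the aromatic nitrogen, and a number 12.3 percentage points lower from compound 1 to compound 3 (beyond the scatter) concerns only the bromo on the benzyl ring. Since compound 4 keeps the benzyl and the nitrogen on the aromatic ring of compound 3, only a small step is expected, estimated at a number 5.6 percentage points lower from compound 3 to compound 4 (within the scatter), with movement in either direction possible. Compound 4 is expected to give 78%, within 60% to 92%.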

Compound 4, a percentage reported as inhibition, at one concentration (the size of the read-out at that concentration, not a potency): 57.8%
Compound 4: middle estimate off by 20.2 percentage points, on the high side, outside the stated range (below it).
By their numbers in this assay, from the lowest: compound 2; then compound 4; then compound 3; then compound 1.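

The ethyl chain on the aromatic nitrogen is not a silent position in this assay: with the benzyl kept in place, ethyl to 2-(dimethylamino)ethyl gives a number 25.8 percentage points lower from compound 3 to compound 4 (beyond the scatter). The read-out therefore responds to a change on the saturated chain carbon, two bonds along the chain from a nitrogen on an aromatic ring, and not only to exchange of the whole group on that nitrogen or to the bromo on the benzyl ring. Nothing available bears on why the read-out falls with this change.

On these data alone, it remains open whether the fall follows the dimethylamino group itself or the longer chain; a propyl, 2-methoxyethyl or 2-hydroxyethyl chain on the same nitrogen would help separate the two. As far as these compounds go, it is also open whether a bromo on the benzyl ring would raise the read-out with the 2-(dimethylamino)ethyl chain in place.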